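Amide variation on a pyrazole-based reductase inhibitor series

This account rests on a few compounds, and the source may have more. Where it says the series, first, only, none or still open, it means among the compounds named here.

Measured compounds:
compound 1 `CC(C)c1c(C(=O)NCc2ccccc2)nn(-c2ccc(F)cc2)c1OC[C@@H](O)C[C@@H](O)CC(=O)O`, 3.8 nM
compound 2 `CC(C)c1c(C(=O)N2CCCC2c2ccccc2)nn(-c2ccc(F)cc2)c1OC[C@@H](O)C[C@@H](O)CC(=O)O`, 14 nM
compound 3 `CC(C)c1c(C(=O)N2CCC[C@H](c3ccccc3)C2)nn(-c2ccc(F)cc2)c1OC[C@@H](O)C[C@@H](O)CC(=O)O`, 4.8 nM

In an assay on microsomes from liver for inhibition of 3-hydroxy-3-methylglutaryl-coenzyme A reductase (Rattus norvegicus) (on this read-out lower numbers stand for stronger inhibition and higher numbers for weaker inhibition), compound 1 gives the lowest number of the three. Compound 3, with 3-phenylpiperidin-1-yl in place of benzylamino on the carbonyl carbon, sits close to it: a 1.3-fold higher number from compound 1 to compound 3 (0.10 log units; within the scatter). Compound 2 falls further away: a 3.7-fold higher number from compound 1 to compound 2 (0.57 log units; beyond the scatter), and between the two cyclic amides the step is a 2.9-fold lower number from compound 2 to compound 3 (0.46 log units; beyond the scatter).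

Compound 4 `Cc1ccccc1CNC(=O)c1nn(-c2ccc(F)cc2)c(OC[C@@H](O)C[C@@H](O)CC(=O)O)c1C(C)C` keeps the benzylamino amide of compound 1 and differs from it only by methyl in place of hydrogen on an aromatic carbon.

Going by the values given here, none of the measured steps touches this position; all three concern the amine part of the amide, so they do not bear directly on the change to compound 4. With the amide intact, no large shift is expected in this assay. The expected step is a 1.2-fold higher number from compound 1 to compound 4 (0.07 log units; within the scatter), a change within the scatter. Compound 4 is therefore estimated at 4.5 nM, within 1.8 nM to 11 nM.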

Compound 4, half-maximal inhibitory concentration: 17 nM
Compound 4: middle estimate off by 3.8-fold (0.58 log units), on the low side; measured number above the stated range.
By their numbers in this assay, from the lowest: compounds 1 and 3 (each within the scatter of the next); then compounds 2 and 4 (each within the scatter of the next).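

In this assay, this position on the benzyl ring is not neutral to substitution: methyl ortho to a large group, turning benzylamino into (2-methylbenzyl)amino, gives a clear step (a 4.5-fold higher number from compound 1 to compound 4 (0.65 log units; beyond the scatter)). This one added methyl leaves compound 4 apart from the 3-phenylpiperidin-1-yl amide (a 3.5-fold higher number from compound 3 to compound 4 (0.55 log units; beyond the scatter)) but not from the 2-phenylpyrrolidin-1-yl amide (a 1.2-fold higher number from compound 2 to compound 4 (0.08 log units; within the scatter)), so a small change on the aromatic ring can matter as much here as replacing the whole amine part of the amide. No measurement available here accounts for the step.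

The compounds shown leave open whether the step is specific to methyl or also follows from another group at this place, such as fluoro, chloro or methoxy. They also leave open how ethyl at this place would compare.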